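The source may report more compounds than this note shows. Statements on the series, on what has been measured and on what is new or still open speak of the compounds shown alone.

Measured in a functional assay on KB 3-1 cells (Homo sapiens) for inhibition, with a stated time of 72 h; on this read-out lower numbers stand for stronger inhibition and higher numbers for weaker inhibition:
- compound 1 `CC(=O)Oc1c(O)cc2oc(-c3ccccc3)cc(=O)c2c1O`: 61600 nM
- compound 2 `CCCOc1c(O)cc2oc(-c3ccccc3)cc(=O)c2c1O`: > 100000 nM (a limit)

In this assay compound 2 stands at > 100000 nM, which is a limit and not a number. This gives only a floor for any step that starts from compound 2.

Compound 3 `CCCOc1cc2oc(-c3ccccc3)cc(=O)c2c(O)c1OCCC` carries propyl in place of hydrogen on an oxygen on an aromatic ring, so that a hydroxy becomes propoxy (propyl in place of hydrogen on an oxygen on an aromatic ring).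

Within the data shown here, one measured step bears on this change, since it also places propyl on an oxygen on an aromatic ring, there in place of acetyl. That step is an at least 1.6-fold higher number from compound 1 to compound 2 (0.21 log units; that floor lies within the scatter). It shows no change beyond the scatter, so no step beyond the scatter is expected here, in either direction.

Compound 3 is expected at about 100000 nM, with an estimated range of 40000 nM to 250000 nM. The expected step is a number no higher from compound 2 to compound 3 (the limit leaves the size open).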

Compound 3, half-maximal inhibitory concentration: > 100000 nM
Compound 3: only a limit was reported; the forecaster's own chance of this, stated with the estimate: 65%; the middle value sits exactly at the limit.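

Compound 3 gives > 100000 nM, a limit and not a number, as compound 2 also does, so no step can be read between them. The compounds shown leave open whether propyl in place of hydrogen on an oxygen on an aromatic ring changes inhibition at all.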